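Aryl dithiocarbamate series: removing the aromatic methyl

The source may hold more compounds than are shown below. What is called first, only, known or untested is meant among the compounds shown, and "the series" means these compounds.

Going by the values given here, compound 1 `CCNC(=S)SCC1=CCOC1=O` and compound 2 `Cc1ccc(NC(=S)SCC2=CCOC2=O)cc1` are the two measured members. In a functional assay on PC-3 cells (Homo sapiens) for antiproliferative activity, read by MTT assay, with a stated time of 72 h (on this read-out lower numbers stand for stronger inhibition and higher numbers for weaker inhibition), compound 1 gives 30600 nM; compound 2 gives 93500 nM, the higher of the two numbers, with compound 1 its nearest neighbour. Compound 3 `O=C1OCC=C1CSC(=S)Nc1ccccc1` is not yet measured. It differs from compound 2 by hydrogen in place of methyl on an aromatic carbon, para to a large group. Among the compounds with values here, no measured pair shows this change, so the expected step from compound 2 to compound 3 is a 1.2-fold lower number from compound 2 to compound 3 (0.07 log units; within the scatter), small, without a confident direction and likely within the scatter. Compound 3 is expected to give 80000 nM in this assay, between 30000 nM and 250000 nM.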

Compound 3, half-maximal inhibitory concentration: 186000 nM
Compound 3: the middle estimate sits 2.3-fold (0.37 log units) below what was measured; the measured number falls inside the stated range.
By their numbers in this assay, from the lowest: compound 1; then compounds 2 and 3 (each within the scatter of the next).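

In this assay, going by these compounds alone, hydrogen in place of methyl on an aromatic carbon, para to a large group, gives the first single-place step: a 2.0-fold higher number from compound 2 to compound 3 (0.30 log units; within the scatter). At this position, then, the methyl can be exchanged for hydrogen without a step beyond the scatter. No available measurement bears on the reason for this reading.

Still open, on these data alone, is whether methoxy, chlorine or an amine on the same aromatic carbon would move the number beyond the scatter. As far as these compounds go, a carboxylic acid there is equally open.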